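Swapping Benzyloxy for Amino on a Urea Inhibitor

This account rests on a few compounds, and the source may have more. Where it says the series, first, only, none or still open, it means among the compounds named here.

Compound 1 `COc1cccc(C2(CNC(=O)Nc3c(C(C)C)cccc3C(C)C)CCCC2)c1` and compound 2 `CC(C)c1cccc(C(C)C)c1NC(=O)NCC1(c2cccc(OCc3ccccc3)c2)CCCC1` share the same core and differ in one place. In an assay on microsomes for inhibition of acyl-CoA:cholesterol acyltransferase (Oryctolagus cuniculus) (a higher number here means a weaker inhibitor, a lower number a stronger inhibitor), compound 1 gives 13 nM, and in this assay compound 2 gives 30 nM. For the measured compounds named here, compound 2 thus stands highest of the two numbers, and the single step between them, a 2.3-fold higher number from compound 1 to compound 2 (0.36 log units; beyond the scatter), shows that building the methoxy out to benzyloxy weakened inhibition modestly. Compound 3 `CC(C)c1cccc(C(C)C)c1NC(=O)NCC1(c2cccc(N)c2)CCCC1` now differs from compound 2 by amino in place of benzyloxy on an aromatic carbon. Going by the values given here, no measured step involves an amino group, so the only guidance is the step from compound 1 to compound 2: removing the phenyl portion pointed toward lower numbers, but the amino group itself is untested here, so the direction is uncertain. Compound 3 is therefore expected to show a 1.5-fold lower number from compound 2 to compound 3 (0.18 log units; within the scatter), with an estimated value of 20 nM and a range from 6 nM to 70 nM.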

Compound 3, half-maximal inhibitory concentration: 21 nM
Beside the measured number, compound 3's estimate is 1.1-fold (0.02 log units) below it; the range from low to high includes it.
By their numbers in this assay, from the lowest: compounds 1, 3 and 2 (each within the scatter of the next, the first and the last beyond it).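

In this assay, replacing benzyloxy, with 8 heavy atoms and an aromatic ring, by amino, with 1 heavy atom and no ring, gives a 1.4-fold lower number from compound 2 to compound 3 (0.15 log units; within the scatter), so cutting this group down to a single atom leaves a number that cannot be told apart from that of compound 2. Amino in place of methoxy gives a 1.6-fold higher number from compound 1 to compound 3 (0.21 log units; within the scatter), so compound 3 also cannot be told apart from compound 1, although a 2.3-fold higher number from compound 1 to compound 2 (0.36 log units; beyond the scatter) separates the two ethers. On this aromatic carbon, then, amino, which brings a hydrogen-bond donor that neither methoxy nor benzyloxy has, gives a number within the scatter of both.

On these data alone, whether a carboxylic acid or an acetamide on this carbon would stay in the same range remains open. Nothing shown gives a measured reason for how closely these numbers agree.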